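Changing the amide end of an antiproliferative chain

The source may hold more compounds than are shown below. What is called first, only, known or untested is meant among the compounds shown, and "the series" means these compounds.

Compound 1 `COc1cccc(-c2nn(-c3ccccc3)cc2-c2ccnc(NCCCNC(=O)c3cccc(C(F)(F)F)c3)c2)c1`: 2200 nM
Compound 2 `COc1cccc(-c2nn(-c3ccccc3)cc2-c2ccnc(NCCNC(=O)Nc3cccc(C(F)(F)F)c3)c2)c1`: 1530 nM

In a functional assay on RXF 393 cells (Homo sapiens) for antiproliferative activity (a higher number here means a weaker inhibitor of growth, a lower number a stronger inhibitor of growth), compound 1 gives 2200 nM and compound 2 gives 1530 nM. Compound 1 holds the upper of these two numbers, yet its gap to compound 2 lies within the scatter, so the two cannot be told apart. Compound 3 `COc1cccc(-c2nn(-c3ccccc3)cc2-c2ccnc(NCCCNC(=O)Nc3ccc(Cl)c(Cl)c3)c2)c1` is not yet measured. It differs from compound 1 by (3,4-dichlorophenyl)amino in place of 3-(trifluoromethyl)phenyl on a carbonyl carbon, so a (3,4-dichlorophenyl)carbamoyl group stands where the (3-(trifluoromethyl)phenyl)carbonyl stood. Within the data shown here, no measured pair covers this change, so no step beyond the scatter is expected. The step of a 1.4-fold lower number from compound 1 to compound 3 (0.14 log units; within the scatter) is estimated to be small. Compound 3 is expected to give about 1600 nM, between 500 nM and 5000 nM.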

Compound 3, concentration for 50% growth inhibition: 1800 nM
Compound 3: the middle estimate sits 1.1-fold (0.05 log units) below what was measured, and the stated range covers the measured number.
By their numbers in this assay, from the lowest: compounds 2, 3 and 1 (each within the scatter of the next).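

In this assay, placing (3,4-dichlorophenyl)amino where 3-(trifluoromethyl)phenyl stood on the carbonyl carbon gives a 1.2-fold lower number from compound 1 to compound 3 (0.09 log units; within the scatter). This first single-place comparison shows that this exchange of end groups, which also brings in a hydrogen-bond donor, leaves the two compounds indistinguishable. No available measurement offers an explanation for this result. From the compounds shown here alone, the amino nitrogen and the two chlorines enter together, so their separate contributions remain open. Also open, going by these compounds, is how a carboxylic acid or a morpholine at this end of the chain would read out.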